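Swapping a Cyclobutyl for a Pyridine on the Amide

The source may hold more compounds than are shown below. What is called first, only, known or untested is meant among the compounds shown, and "the series" means these compounds.

Of the compounds shown here, two that share a core have been measured in an assay on HEK293 cells for agonist activity at Toll-like receptor 8 (Homo sapiens), read by a luciferase reporter, with a stated time of 6 h; on this read-out higher numbers stand for an effect only at larger amounts of compound and lower numbers for an effect already at smaller amounts. Compound 1 `CCCCNc1nc(N)nc2c1CN(Cc1cccnc1)CC2` carries a (pyridin-3-yl)methyl group on an amine nitrogen in a ring, and in this assay compound 1 gives 0.13 uM. Compound 2 `CCCCNc1nc(N)nc2c1CN(C(=O)C1CCC1)CC2` carries a cyclobutylcarbonyl group in the same place, and in this assay compound 2 gives 0.4 uM. Among the compounds with values here, the single step between them, a 3.1-fold higher number from compound 1 to compound 2 (0.49 log units; beyond the scatter), makes compound 2 the one with the higher of the two numbers.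

Compound 3 `CCCCNc1nc(N)nc2c1CN(C(=O)c1ccncc1)CC2` differs from compound 2 in one place: pyridin-4-yl in place of cyclobutyl on a carbonyl carbon. This change keeps the carbonyl of compound 2 while bringing back a pyridine ring, as compound 1 had, though as pyridin-4-yl and cut one bond further out, reading cyclobutylcarbonyl to (pyridin-4-yl)carbonyl. Within the data shown here, only the step from compound 1 to compound 2 bears on it, and only loosely, since that step changed both the ring and the carbonyl together. On that basis a small movement toward lower numbers is expected, with the possibility that it stays within the scatter. The step from compound 2 to compound 3 is estimated at a 1.6-fold lower number from compound 2 to compound 3 (0.20 log units; within the scatter). Compound 3 is therefore expected to give about 0.25 uM, within a range from 0.08 uM to 0.8 uM.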

Compound 3, minimum effective concentration: > 25 uM
Compound 3: no number, only a limit; the forecaster's own chance of this, stated with the estimate: 5%; middle value at least 100-fold (2.00 log units) away from the limit.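

In this assay the reading for compound 3 is a limit of the assay and not a number: the limit of > 25 uM in this assay, at which 1 of the 3 values shown sits. Even so, the change on this carbonyl carbon is far from minor: replacing cyclobutyl with pyridin-4-yl gives an at least 62-fold higher number from compound 2 to compound 3 (1.79 log units; beyond the scatter), a large step, whereas the earlier pair had shown only a modest one. A pyridine ring alone therefore does not bring back a low number, and the step from the (pyridin-3-yl)methyl group to the (pyridin-4-yl)carbonyl group is an at least 190-fold higher number from compound 1 to compound 3 (2.28 log units; beyond the scatter), although that change alters the ring and the carbonyl together.

The compounds shown leave open whether this jump belongs to the ring nitrogen, to the aromatic ring as a whole, or to the place of the nitrogen within the ring, and a phenyl or a pyridin-3-yl group on the same carbonyl carbon would help tell these apart. They also leave open whether a (pyridin-4-yl)methyl group on the amine nitrogen in the ring would give a number close to that of compound 1, at 0.13 uM.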